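Swapping Trifluoromethyl for Trifluoromethoxy on a Second Core

This account rests on a few compounds, and the source may have more. Where it says the series, first, only, none or still open, it means among the compounds named here.

Of the compounds shown here, three have so far been measured in a functional assay on DU-145 cells (Homo sapiens) for antiproliferative activity, read by propidium iodide staining, with a stated time of 96 h; a higher number here means a weaker inhibitor, a lower number a stronger inhibitor. Compound 1 `CC(O)(CSc1ccc(C(F)(F)F)cc1)C(=O)Nc1cccc(S(F)(F)(F)(F)F)c1` gives 27200 nM. Compound 2 `CC(O)(CSc1ccc(OC(F)(F)F)cc1)C(=O)Nc1cccc(S(F)(F)(F)(F)F)c1` differs from compound 1 in one place, described as trifluoromethoxy in place of trifluoromethyl on an aromatic carbon. In this assay compound 2 gives 24700 nM. The step is a 1.1-fold lower number from compound 1 to compound 2 (0.04 log units; within the scatter), so the two values cannot be told apart.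

Compound 3 `CC(O)(COc1cccc(C(F)(F)F)c1)C(=O)Nc1ccc(S(F)(F)(F)(F)F)cc1` is built on a different core; the difference between the two cores is not broken down here. In this assay compound 3 gives 21900 nM. The values of compound 3 and compound 2 lie within the scatter of each other, as do those of compound 3 and compound 1, so none of the three can be called stronger or weaker than another.

Compound 4 `CC(O)(COc1cccc(OC(F)(F)F)c1)C(=O)Nc1ccc(S(F)(F)(F)(F)F)cc1` has not yet been measured. It differs from compound 3 by trifluoromethoxy in place of trifluoromethyl on an aromatic carbon. This is the same kind of change as from compound 1 to compound 2, but not the same: in the earlier pair the group sits para to a large group, here meta to a large group. Because the earlier pair moved by a 1.1-fold lower number from compound 1 to compound 2 (0.04 log units; within the scatter), the step from compound 3 to compound 4 is expected to be about a 1.0-fold lower number from compound 3 to compound 4 (0.02 log units; within the scatter). Compound 4 is therefore estimated at 21000 nM, most likely between 10000 nM and 45000 nM.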

Compound 4, half-maximal inhibitory concentration: 18400 nM
Compound 4: the middle estimate sits 1.1-fold (0.06 log units) above what was measured; the range from low to high includes it.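

In this assay, trifluoromethoxy in place of trifluoromethyl on the core of compound 3 gives a 1.2-fold lower number from compound 3 to compound 4 (0.08 log units; within the scatter), so the two values cannot be told apart. Set beside the same swap on the core of compound 1, the new step agrees with the earlier one, and in this small set the swap carries over from one core to the other without any step that can be read as a real effect: the same change on two cores in this assay, a 1.1-fold lower number (0.04 log units; within the scatter) from compound 1 to compound 2 and a 1.2-fold lower number (0.08 log units; within the scatter) from compound 3 to compound 4, 1.1-fold (0.03 log units) apart, within the scatter of two such steps. Going by these compounds alone, this shows only that the two groups could be exchanged on these two cores without leaving the scatter; it does not show that either group is the better one, even though both steps point the same way, and two pairs cannot establish that the same would hold on a third core or at another place on the ring.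

The compounds shown carry only trifluoromethyl or trifluoromethoxy at this place, so it remains open whether a quite different group, such as an amine, a carboxylic acid or a longer alkyl chain, would move the number beyond the scatter. Within the data shown here, no pair here differs in one place between the two cores, so what each part of the core contributes also remains open.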